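This account rests on a few compounds, and the source may have more. Where it says the series, first, only, none or still open, it means among the compounds named here.

Measured compounds:
Compound 1 `C=CCNC(=O)n1c(-c2ccc(OC)cc2)cc(=O)c2c(OC)cc(OC)cc21`: in a functional assay on HepG2 cells (Homo sapiens) for antiproliferative activity, with a stated time of 72 h (on this read-out lower numbers stand for an effect already at smaller amounts and higher numbers for an effect only at larger amounts of compound), compound 1 gives only a limit, > 20000 nM.
Compound 2 `COc1ccc(-c2cc(=O)c3c(OC)cc(OC)cc3n2S(=O)(=O)c2ccc(C#N)cc2)cc1`: in this assay compound 2 gives only a limit, > 17200 nM.
Compound 3 `COc1ccc(-c2cc(=O)c3c(OC)cc(OC)cc3n2S(=O)(=O)c2cc(F)c(F)c(F)c2)cc1`: in this assay compound 3 gives only a limit, > 65500 nM.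

Every value in the set is a limit of this assay rather than a number (the limit of > 17200 nM in this assay, at which 1 of the 3 values shown sits, (the limit of > 20000 nM in this assay, at which 1 of the 3 values shown sits), (the limit of > 65500 nM in this assay, at which 1 of the 3 values shown sits)), so compound 3 cannot be ranked against compound 1 or compound 2; all that can be said is that none of the three yields a measurable half-maximal effective concentration.

The next compound is compound 4 `COc1ccc(-c2cc(=O)c3c(OC)cc(OC)cc3n2S(=O)(=O)c2ccc(Br)cc2)cc1`, reached by the change (4-bromophenyl in place of 3,4,5-trifluorophenyl on a sulfonyl sulfur). The two measured steps, a step that the two limits leave unreadable from compound 1 to compound 2 and a step that the two limits leave unreadable from compound 2 to compound 3, both run between limits and give no readable size or direction. They therefore offer no guidance on the size of a step in this assay for the exchange at the sulfonyl sulfur, and no step beyond the scatter is expected in either direction.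

Compound 4 is estimated at 40000 nM, with a range from 8000 nM to 150000 nM, most probably again reported as a limit. The implied step an at least 1.6-fold lower number from compound 3 to compound 4 (0.21 log units; that floor lies within the scatter) is an expectation only, and not one beyond the scatter.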

Compound 4, half-maximal effective concentration: 16300 nM
Estimate against measurement, compound 4: 2.5-fold (0.39 log units) above, within the range that was stated.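

In this assay the set now holds a number rather than only limits, which gives the exchange on a sulfonyl sulfur its first readable floor: an at least 4.0-fold lower number from compound 3 to compound 4 (0.60 log units; beyond the scatter). The other two comparisons give floors only, an at least 1.0-fold lower number from compound 2 to compound 4 (0.02 log units; that floor lies within the scatter) for bromo in place of cyano and an at least 1.2-fold lower number from compound 1 to compound 4 (0.08 log units; that floor lies within the scatter) for (4-bromophenyl)sulfonyl in place of allylcarbamoyl, so neither establishes an order. The first of these three steps also stays a floor, because the value of compound 3 is a limit: the limit of > 65500 nM in this assay, at which 1 of the 4 values shown sits.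

Going by these compounds, the steps among compound 1, compound 2 and compound 3 cannot be read, so it remains open how much of the result belongs to 4-bromophenyl itself. Also open, on these data alone, is how an amine or a carboxylic acid on the phenyl ring, or a longer chain on the sulfonyl sulfur, would read out in this assay.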